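The source may hold more compounds than are shown below. What is called first, only, known or untested is meant among the compounds shown, and "the series" means these compounds.

In a functional assay on the whole organism with Rattus norvegicus as the target (a higher number here means that more compound is needed for the effect, a lower number that less compound is needed), three compounds sharing one core and differing in the groups on the amine nitrogen have been measured. Compound 1 (`COc1cc(N)c(Cl)cc1C(=O)NCCN(C)C(C)c1ccccc1`) gives 1 mg/kg, compound 2 (`COc1cc(N)c(Cl)cc1C(=O)NCCN(C)CC1CCCCC1`) gives 3 mg/kg, and compound 3 (`CCN(CCNC(=O)c1cc(Cl)c(N)cc1OC)Cc1ccccc1OC`) gives 10 mg/kg, the highest number of the three.

Compound 4 (`CCN(CCNC(=O)c1cc(Cl)c(N)cc1OC)Cc1ccc(Cl)cc1`) has not yet been measured. It carries 4-chlorophenyl in place of the 2-methoxyphenyl of compound 3, on a saturated chain carbon bound to an amine nitrogen (4-chlorophenyl in place of 2-methoxyphenyl on a saturated chain carbon bound to an amine nitrogen).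

Among the measured compounds shown here, no measured step makes this exact exchange. The only one that bears on it is a 3.0-fold higher number from compound 1 to compound 2 (0.48 log units; beyond the scatter), where cyclohexylmethyl takes the place of 1-phenylethyl on an amine nitrogen. That single step shows that a change on this nitrogen can move the number modestly, but it says little about direction. For the measured compounds named here, with compound 3 at 10 mg/kg, the highest value so far, a modest shift towards a lower number in this assay is expected, with only weak support. The expected change is a 2.0-fold lower number from compound 3 to compound 4 (0.30 log units; within the scatter). The estimate for compound 4 is 5 mg/kg, with an expected range from 1.5 mg/kg to 15 mg/kg.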

Compound 4, dose for half-maximal effect: 0.24 mg/kg
Estimate against measurement, compound 4: 21-fold (1.32 log units) above, and the stated range ends above it.
By their numbers in this assay, from the lowest: compound 4; then compound 1; then compound 2; then compound 3.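

In this assay, putting 4-chlorophenyl in place of 2-methoxyphenyl on a saturated chain carbon bound to an amine nitrogen gives a 42-fold lower number from compound 3 to compound 4 (1.62 log units; beyond the scatter) in a single large step. The earlier compounds shown here offered only a 3.0-fold higher number from compound 1 to compound 2 (0.48 log units; beyond the scatter) as a modest step at an amine nitrogen, whereas this exchange shows that the aryl group on this chain carbon can move the required dose much further, and here towards less compound. No measurement at hand accounts for this step.

The compounds shown leave open how much of the step belongs to the loss of the methoxy group and how much to the gain of the chlorine, as both change in this one exchange. From the compounds shown here alone, a plain phenyl on the same carbon, or a trifluoromethyl group on the ring in place of the chlorine, remains open too.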